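The source may hold more compounds than are shown below. What is called first, only, known or untested is meant among the compounds shown, and "the series" means these compounds.

Notes on the amide series

Compound 1 `N[C@H]1CC[C@H](Nc2c(C(=O)NCc3ccc(Cl)cc3)nc(Br)c3cccnc23)CC1` is the reference point: in a functional assay on SK-BR-3 cells (Homo sapiens) for cytotoxicity, read by MTT assay, with a stated time of 72 h (on this read-out higher numbers stand for weaker inhibition and lower numbers for stronger inhibition), compound 1 gives 2000 nM. Compound 2 `N[C@H]1CC[C@H](Nc2c(C(=O)NCc3cccc(C(F)(F)F)c3)nc(Br)c3cccnc23)CC1`, with the same core, has no number in this assay; for compound 2 the entry reads "not determined" (no result reported). Compound 3 `N[C@H]1CC[C@H](Nc2c(C(=O)Nc3ccccc3)nc(Br)c3cccnc23)CC1` carries a phenyl in place of the 4-chlorobenzyl on the amide-type nitrogen, and in this assay compound 3 gives 2000 nM, level with compound 1 at the digits printed. Among the compounds with values here, the single step on record, no change at the digits printed from compound 1 to compound 3 (within the scatter), is within the scatter; it is the only step with a single number on each side.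

Compound 4 `N[C@H]1CC[C@H](Nc2c(C(=O)NC3CCCCC3)nc(Br)c3cccnc23)CC1` differs from compound 3 by cyclohexyl in place of phenyl on an amide-type nitrogen. Within the data shown here, the one measured step, from compound 1 to compound 3, also changed the group on the amide-type nitrogen and left the read-out unchanged, so a step of similar size, none beyond the scatter, is expected for no change at the digits printed from compound 3 to compound 4 (within the scatter). Compound 4 is therefore estimated at 2000 nM in this assay, within a range from 800 nM to 6000 nM.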

Compound 4, half-maximal inhibitory concentration: 4200 nM
The estimate for compound 4 lay 2.1-fold (0.32 log units) below the measured number; measured number inside the range.
By their numbers in this assay, from the lowest: compounds 1 and 3 (each within the scatter of the next); then compound 4.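

In this assay, within the data shown here, the group on the amide-type nitrogen shifts the read-out for the first time, with cyclohexyl in place of phenyl giving a 2.1-fold higher number from compound 3 to compound 4 (0.32 log units; beyond the scatter), although the two groups match in heavy atoms and differ in the ring being non-aromatic rather than aromatic. Cyclohexyl in place of 4-chlorobenzyl gives the same modest change, a 2.1-fold higher number from compound 1 to compound 4 (0.32 log units; beyond the scatter), so this position is not indifferent to the group it carries, even though phenyl and 4-chlorobenzyl remain level. No measurement at hand accounts for this shift.

Among these compounds, whether the higher number follows from the loss of the aromatic ring itself remains open, since only one non-aromatic group stands here. As far as these compounds go, how an amine, a carboxylic acid or a longer alkyl chain on the amide-type nitrogen would read also remains open.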